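The source may report more compounds than this note shows. Statements on the series, on what has been measured and on what is new or still open speak of the compounds shown alone.

Values in an ADME assay on microsomes from liver (Mus musculus) for metabolic stability, read by LC-MS, with a stated time of 30 min, tested at 1 uM; on this read-out lower numbers stand for a less stable compound and higher numbers for a more stable compound:
- compound 1 `O=C(NCc1ccc(S(=O)(=O)c2ccccc2)cc1)c1cc2ccncc2s1`: 21%
- compound 2 `O=C(NCc1ccc(S(=O)(=O)c2ccccc2)cc1)c1cc2ncccc2s1`: 1.6%
- compound 3 `O=C(NCc1ccc(S(=O)(=O)c2cccc(F)c2)cc1)c1cc2cnccc2[nH]1`: 44%

Compound 1 stands second highest of the three numbers, with compound 2 lower and compound 3 higher. Compound 4 `O=C(NCc1ccc(S(=O)(=O)c2ccccc2)cc1)c1ccc2nccn2c1` is still unmeasured. Its change from compound 1 is a group of 9 heavy atoms (7 carbon, 2 nitrogen; one five-membered aromatic ring with 2 hetero atoms, one six-membered aromatic ring with 1 hetero atom) in place of a group of 9 heavy atoms (7 carbon, 1 nitrogen, 1 sulfur; one five-membered aromatic ring with 1 hetero atom, one six-membered aromatic ring with 1 hetero atom), on a carbonyl carbon.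

Within the data shown here, one measured step bears on this: a number 19.4 percentage points lower from compound 1 to compound 2 (beyond the scatter), an exchange at the same carbonyl carbon. It shows that this group alone can move the read-out, but gives no direction for compound 4. Among the measured compounds shown here, compound 3 differs from compound 1 in more than one place, so it offers no clean step.

The expected change is small, with little confidence in its direction: a number 4 percentage points higher from compound 1 to compound 4 (within the scatter). Compound 4 is estimated at 25%, with an expected range of 8% to 50%.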

Compound 4, percent of the compound remaining: 18%
Compound 4: middle estimate off by 7 percentage points, on the high side, within the range that was stated.
By their numbers in this assay, from the lowest: compound 2; then compounds 4 and 1 (each within the scatter of the next); then compound 3.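

At the carbonyl carbon, a group of 7 carbon and 2 nitrogen atoms replaces the sulfur-containing group with a number 3 percentage points lower from compound 1 to compound 4 (within the scatter) in this assay, so sulfur is not needed at this position to match compound 1. The same exchange gives a number 16.4 percentage points higher from compound 2 to compound 4 (beyond the scatter), so the presence of sulfur alone does not set the read-out: compound 1 and compound 2 both carry it, yet only compound 2 lies beyond the scatter from compound 4. No available measurement explains these steps.

On these data alone, how a piperidine at this carbonyl carbon would read remains open.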